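The source may report more compounds than this note shows. Statements on the series, on what has been measured and on what is new or still open speak of the compounds shown alone.

Compound 2 `O=C(NNc1ccccc1)c1cc2ccccc2oc1=O` gives 41400 nM in an in vitro assay on BTI-TN-5B1-4 cells for inhibition of Amine oxidase [flavin-containing] A (Homo sapiens), read by fluorescence, with a stated time of 15 min (on this read-out lower numbers stand for stronger inhibition and higher numbers for weaker inhibition), and stands second highest of the three numbers; compound 3 `O=C(NNc1ccccc1[N+](=O)[O-])c1cc2ccccc2oc1=O` is nearest with 39600 nM, and compound 1 `O=C(c1ccccc1)c1cc2cc(O)ccc2oc1=O` is furthest with 51700 nM, both within the scatter of compound 2. Compound 4 `O=C(NNc1ccc(Cl)cc1)c1cc2ccccc2oc1=O` differs from compound 2 by chloro in place of hydrogen on an aromatic carbon. For the measured compounds named here, no measured step introduces a chloro group. Going by the values given here, the one step that bears on it, a substitution on the same aromatic ring, is a 1.0-fold lower number from compound 2 to compound 3 (0.02 log units; within the scatter), which lies within the scatter. Compound 4 is therefore expected to show no change beyond the scatter, an expected step of a 1.0-fold lower number from compound 2 to compound 4 (0.01 log units; within the scatter). The estimate for compound 4 is 40000 nM, with a range from 20000 nM to 80000 nM.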

Compound 4, half-maximal inhibitory concentration: 48000 nM
For compound 4 the middle estimate is 1.2-fold (0.08 log units) below the measured one; the range from low to high includes it.
By their numbers in this assay, from the lowest: compounds 3, 2, 4 and 1 (each within the scatter of the next).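

With chloro on an aromatic carbon para to a large group, the change from phenyl to 4-chlorophenyl gives (a 1.2-fold higher number from compound 2 to compound 4 (0.06 log units; within the scatter)) in this assay, a step that lies within the scatter. This adds a second substitution on this aromatic ring, and a first at this position, that leaves no readable change, alongside the nitro step (a 1.0-fold lower number from compound 2 to compound 3 (0.02 log units; within the scatter)). No measurement offers an explanation for this result. The compounds shown leave open whether an amine or a carboxylic acid on this carbon would move the number beyond the scatter.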